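A few compounds are considered here, and "the series" means these few. Any claim that something is new, unique, unknown or untested is made for them only; others in the source may bear on it.

Compound 1 `CC(=O)OCCO[C@H](CC=C(C)C)C1=CC(=O)c2c(O)ccc(O)c2C1=O`: 15500 nM
Compound 2 `CC(C)=CC[C@@H](OC(=O)CC(O)c1ccccc1)C1=CC(=O)c2c(O)ccc(O)c2C1=O`: 17000 nM

Both values come from a functional assay on DU-145 cells (Homo sapiens) for cytotoxicity, read by MTT assay; a higher number here means a weaker inhibitor, a lower number a stronger inhibitor. Compound 2, at 17000 nM, stands level with compound 1, at 15500 nM, since the two numbers lie within the usual scatter of each other. The pair therefore sets no order. Going by the values given here, the two compounds share a core but differ in the chain attached to it, and no single-place step between measured compounds is available to show what one such change does.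

Compound 3 `CC(C)=CC[C@@H](OC(=O)C1CCOC1)C1=CC(=O)c2c(O)ccc(O)c2C1=O` comes from compound 2 through one change on a carbonyl carbon, with oxolan-3-yl in place of 2-hydroxy-2-phenylethyl on a carbonyl carbon. The expectation rests only on the agreement of compound 1 at 15500 nM and compound 2 at 17000 nM, despite their different chains. On that basis, the expected step, a 1.3-fold lower number from compound 2 to compound 3 (0.12 log units; within the scatter), leans slightly toward a lower number in this assay but is not expected to go beyond the scatter. The estimated value for compound 3 is 13000 nM, with an expected range from 6000 nM to 27000 nM.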

Compound 3, half-maximal inhibitory concentration: 47500 nM
Compound 3: the middle estimate sits 3.7-fold (0.56 log units) below what was measured; measured number outside the range, above it.
By their numbers in this assay, from the lowest: compounds 1 and 2 (each within the scatter of the next); then compound 3.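

In this assay the exchange of 2-hydroxy-2-phenylethyl for oxolan-3-yl on a carbonyl carbon gives a 2.8-fold higher number from compound 2 to compound 3 (0.45 log units; beyond the scatter) and so shows what the level pair of compound 1 and compound 2 could not: the group at this place can move the number beyond the scatter, here modestly and toward weaker inhibition. The comparison with the other earlier compound, with (oxolan-3-yl)carbonyl in place of 2-acetoxyethyl on an oxygen on a saturated carbon, gives a 3.1-fold higher number from compound 1 to compound 3 (0.49 log units; beyond the scatter) and places compound 3 apart from both compounds that came before it. No measurement among those shown accounts for this shift.

The single change removes the six-membered aromatic ring and the hydrogen-bond donor together and also shortens the group, so the compounds shown leave open which of these differences the number follows. Also open, from the compounds shown here alone, is whether a plain phenyl group, an amine or a carboxylic acid on this carbonyl carbon would stay level with compound 2 or stand nearer to compound 3.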